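A few compounds are considered here, and "the series" means these few. Any claim that something is new, unique, unknown or untested is made for them only; others in the source may bear on it.

Going by the values given here, in a functional assay on MCF7 cells (Homo sapiens) for antiproliferative activity, read by MTT assay, with a stated time of 48 h (on this read-out lower numbers stand for stronger inhibition and higher numbers for weaker inhibition), compound 1 `COc1ccc2c(/C=C/C(=O)c3cc(N)c(OC)c(OC)c3)c[nH]c2c1` gives 249 nM and stands lowest of the three numbers so far. Compound 2 `COc1ccc2c(/C=C/C(=O)c3cc(N)c(OC)c(OC)c3)cn(C)c2c1` at 505 nM and compound 3 `COc1cc(C(=O)/C=C/c2c[nH]c3ccccc23)cc(N)c1OC` at 595 nM both sit higher. Compound 4 `COc1ccc2c(/C=C/C(=O)c3cc(OC)c(OC)c([Se]C)c3)c[nH]c2c1` keeps the core of compound 1 but loses its amino group on an aromatic carbon (a group of 2 heavy atoms (1 carbon, 1 selenium; no ring) in place of one nitrogen atom, on an aromatic carbon). Neither measured step touches that place, so both bear on it only loosely: a 2.0-fold higher number from compound 1 to compound 2 (0.31 log units; beyond the scatter) and a 2.4-fold higher number from compound 1 to compound 3 (0.38 log units; beyond the scatter) were modest, and each led to a higher number. No replacement of the amino group has been measured, so the direction is uncertain, but a modest rise is expected, a 1.4-fold higher number from compound 1 to compound 4 (0.15 log units; within the scatter) as the estimate. The estimated value for compound 4 is 350 nM (expected range 60 nM to 1500 nM).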

Compound 4, half-maximal inhibitory concentration: 83 nM
Compound 4: the middle estimate sits 4.2-fold (0.62 log units) above what was measured; measured number inside the range.
By their numbers in this assay, from the lowest: compound 4; then compound 1; then compounds 2 and 3 (each within the scatter of the next).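

The amino group, on an aromatic carbon ortho to a methoxy group, can be replaced without loss in this assay: the carbon-and-selenium group gives a 3.0-fold lower number from compound 1 to compound 4 (0.48 log units; beyond the scatter). With 0 hydrogen-bond donors and 0 acceptors in the entering group, the amino group's donor and acceptor are not required for this lower number. Nothing available explains the change.

From the compounds shown here alone, whether selenium itself matters stays open, as a methylthio or methoxy group here would be needed to tell. Going by these compounds, the effect of the same replacement on compound 2 is also open.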